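A few compounds are considered here, and "the series" means these few. Any claim that something is new, unique, unknown or untested is made for them only; others in the source may bear on it.

Measured so far:
compound 1 `O=C(CCCCn1[se]c2ccccc2c1=O)NO` — 356 nM
compound 2 `O=C(CCCCCn1[se]c2ccccc2c1=O)NO` — 181 nM

Compound 2 holds the lowest of the two numbers in an assay on isolated protein for inhibition of protein deacetylase HDAC6 (Homo sapiens), read by fluorescence, with stated times of 15 min and 30 min; a lower number here means a stronger inhibitor, a higher number a weaker inhibitor; its nearest neighbour is compound 1, and the step of a 2.0-fold lower number from compound 1 to compound 2 (0.29 log units; within the scatter) lies within the scatter, so the two cannot be ranked against each other.

Compound 3 `O=C(CCCCCCn1[se]c2ccccc2c1=O)NO` differs from compound 2 in one place: (hydroxycarbamoyl)methyl in place of hydroxycarbamoyl on a saturated chain carbon, five bonds along the chain from an aromatic nitrogen. Among the measured compounds shown here, the only measured step that bears on this is a 2.0-fold lower number from compound 1 to compound 2 (0.29 log units; within the scatter), the same kind of chain extension cut one bond further in, which stayed within the scatter. Nothing here supports a change beyond the scatter for compound 3 in this assay. For the measured compounds named here, on the one relevant step, a small move toward a lower number is expected for compound 3, of size a 1.4-fold lower number from compound 2 to compound 3 (0.14 log units; within the scatter), but within the scatter. The expected value for compound 3 in this assay is 130 nM, with a range from 50 nM to 350 nM.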

Compound 3, half-maximal inhibitory concentration: 19 nM
The estimate for compound 3 lay 6.8-fold (0.84 log units) above the measured number; measured number outside the range, below it.
By their numbers in this assay, from the lowest: compound 3; then compounds 2 and 1 (each within the scatter of the next).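

In this assay, the chain extension now produces a readable change: (hydroxycarbamoyl)methyl in place of hydroxycarbamoyl, five bonds along the chain from an aromatic nitrogen, gives a 9.5-fold lower number from compound 2 to compound 3 (0.98 log units; beyond the scatter) and so stands apart from the earlier extension, which gave a 2.0-fold lower number from compound 1 to compound 2 (0.29 log units; within the scatter) and remained inconclusive. Across the whole run, 2-(hydroxycarbamoyl)ethyl in place of hydroxycarbamoyl, four bonds along the chain from an aromatic nitrogen, gives a 19-fold lower number from compound 1 to compound 3 (1.27 log units; beyond the scatter) as the total change, so the response to chain length in these three compounds is uneven, with most of the change arising at the last extension. No measurement available here accounts for this uneven response.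

On these data alone, whether a longer chain would extend this trend or reverse it remains open. Also open, as far as these compounds go, is whether an ether oxygen or an amine within the chain would keep the lower number.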